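Moving from a methylphenyl to a naphthyl sulfonamide

A few compounds are considered here, and "the series" means these few. Any claim that something is new, unique, unknown or untested is made for them only; others in the source may bear on it.

Of the compounds shown here, three sharing one core have been measured in an assay on MDA-MB-231 cells for binding affinity to C-X-C chemokine receptor type 4 (Homo sapiens), read by microscopy, with stated times of 10 min and 30 min; on this read-out lower numbers stand for an effect already at smaller amounts and higher numbers for an effect only at larger amounts of compound. Compound 1 `Cc1cccc(S(=O)(=O)NCc2ccc(CNC(=O)c3ccc(CNc4ncccn4)cc3)cc2)c1` gives 100 nM in this assay, level with compound 3 `Cc1ccc(S(=O)(=O)NCc2ccc(CNC(=O)c3ccc(CNc4ncccn4)cc3)cc2)cc1`, which gives 100 nM; together they stand at the highest numbers of the three, while compound 2 `O=C(NCc1ccc(CNS(=O)(=O)c2cccc(Cl)c2)cc1)c1ccc(CNc2ncccn2)cc1` gives 1 nM, the lowest.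

Compound 4 `O=C(NCc1ccc(CNS(=O)(=O)c2cccc3ccccc23)cc1)c1ccc(CNc2ncccn2)cc1` has not yet been measured. It differs from compound 1 in one place: naphthalen-1-yl in place of 3-methylphenyl on a sulfonyl sulfur. For the measured compounds named here, two measured steps touch the same place. Moving the methyl from one ring position to another brought no change at the digits printed from compound 1 to compound 3 (within the scatter), whereas swapping the methyl for a chloro brought a 100-fold lower number from compound 1 to compound 2 (2.00 log units; beyond the scatter). So the aromatic piece on the sulfonyl sulfur can leave the number unchanged or shift it strongly, and no measured step adds a second fused ring there. The direction for compound 4 is therefore open, and a wide range is appropriate.

Compound 4 is expected to give about 30 nM in this assay, somewhere between 3 nM and 300 nM. That estimate means a step of a 3.3-fold lower number from compound 1 to compound 4 (0.52 log units; beyond the scatter), leaning toward a modest improvement only because compound 2 showed a 100-fold lower number from compound 1 to compound 2 (2.00 log units; beyond the scatter) when the same position was altered.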

Compound 4, effective concentration (reported as EC, without a stated level of effect): 1000 nM
Compound 4: middle estimate off by 33-fold (1.52 log units), on the low side; measured number above the stated range.
By their numbers in this assay, from the lowest: compound 2; then compounds 1 and 3 (each within the scatter of the next); then compound 4.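

In this assay, putting naphthalen-1-yl on the sulfonyl sulfur in place of 3-methylphenyl brings a 10-fold higher number from compound 1 to compound 4 (1.00 log units; beyond the scatter) and, in place of 4-methylphenyl, a 10-fold higher number from compound 3 to compound 4 (1.00 log units; beyond the scatter) in the same direction. The earlier compounds shown here showed only a level step or a fall from compound 1, so this position can also push the number up, and a second fused ring of carbon is a change it does not accept without loss. Set against the 3-chlorophenyl group, the same ring brings a 1000-fold higher number from compound 2 to compound 4 (3.00 log units; beyond the scatter) within this small series, so the aromatic group on this sulfur alone spans the full spread of the four numbers. No measurement at hand explains why this ring behaves as it does.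

As far as these compounds go, it remains open whether a bromo or a methoxy group in place of the chloro of compound 2 would keep the low number. Also open, from the compounds shown here alone, is how a non-aromatic cyclohexyl ring or a pyridine ring on the sulfonyl sulfur would compare with the phenyl and naphthyl groups seen so far.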